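Notes on changes at the carbonyl carbon in this series

The source may report more compounds than this note shows. Statements on the series, on what has been measured and on what is new or still open speak of the compounds shown alone.

Measured so far, in a functional assay on isolated protein for inhibition of Glucose-dependent insulinotropic receptor (Homo sapiens), read by HTRF and cAMP accumulation; on this read-out higher numbers stand for an effect only at larger amounts of compound and lower numbers for an effect already at smaller amounts:
compound 1 `Cc1nc(S(C)(=O)=O)ccc1Oc1ncnc(OC2CCN(C(=O)OC3COC3)CC2)c1F`: 326 nM
compound 2 `Cc1nc(S(C)(=O)=O)ccc1Oc1ncnc(OC2CCN(C(=O)SC3(C)CC3)CC2)c1F`: 13.2 nM
compound 3 `Cc1nc(S(C)(=O)=O)ccc1Oc1ncnc(OC2CCN(C(=O)SC3CCC3)CC2)c1F`: 8.51 nM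

Compound 3 gives the lowest number of the three: a 1.6-fold lower number from compound 2 to compound 3 (0.19 log units; within the scatter), and a 38-fold lower number from compound 1 to compound 3 (1.58 log units; beyond the scatter). Compound 4 `Cc1nc(S(C)(=O)=O)ccc1Oc1ncnc(OC2CCN(C(=O)c3noc(C(C)C)n3)CC2)c1F` differs from compound 3 at the same carbonyl carbon: 5-isopropyl-1,2,4-oxadiazol-3-yl in place of cyclobutylsulfanyl on a carbonyl carbon

Among the measured compounds shown here, the steps that bear on this all sit at that carbonyl carbon: a 25-fold lower number from compound 1 to compound 2 (1.39 log units; beyond the scatter) and a 38-fold lower number from compound 1 to compound 3 (1.58 log units; beyond the scatter) were both large, so the group on the carbonyl carbon moves the read-out strongly in this assay. For the measured compounds named here, no measured compound carries the entering group, so its direction is uncertain; a moderate rise from compound 3 is expected, with wide bounds. For compound 4 the estimated value is 25 nM (range 6 nM to 100 nM), meaning an expected step of a 2.9-fold higher number from compound 3 to compound 4 (0.47 log units; beyond the scatter).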

Compound 4, half-maximal effective concentration: 21.2 nM
Beside the measured number, compound 4's estimate is 1.2-fold (0.07 log units) above it, within the range that was stated.
By their numbers in this assay, from the lowest: compounds 3, 2 and 4 (each within the scatter of the next, the first and the last beyond it); then compound 1.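

In this assay, the carbonyl carbon carries an aromatic 5-isopropyl-1,2,4-oxadiazol-3-yl and still reads close to the sulfanyl compounds, so neither sulfur nor oxygen is required on that carbon: a 2.5-fold higher number from compound 3 to compound 4 (0.40 log units; beyond the scatter) is modest and a 1.6-fold higher number from compound 2 to compound 4 (0.21 log units; within the scatter) lies within the scatter. The oxetanyl carbamate remains well apart, with a 15-fold lower number from compound 1 to compound 4 (1.19 log units; beyond the scatter). Nothing available explains these steps. On these data alone, it remains open what the isopropyl contributes, and how a cyclopropyl or tert-butyl in its place would read. An amine on the carbonyl carbon is also untested among the compounds shown.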